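The compounds below may be only part of what the source reports. "The series", "measured", "known", "first", "only" and "open" are said of these compounds alone.

In a functional assay on NIH3T3 cells (Mus musculus) (a higher number here means that more compound is needed for the effect, a lower number that less compound is needed), compound 3 `Cn1cncc1C(OCc1ccc(C#N)cc1C#CCCc1ccccc1)c1ccc(C#N)cc1` gives 130 nM. Compound 2 `CCC/C=C/C=C/c1cc(C#N)ccc1COC(c1ccc(C#N)cc1)c1cncn1C` gives 16.7 nM in this assay, and the change between them was a 7.8-fold higher number from compound 2 to compound 3 (0.89 log units; beyond the scatter). Compound 1 `Cn1cncc1C(OCc1ccc(C#N)cc1C#Cc1ccccn1)c1ccc(C#N)cc1` reaches only a limit of the assay in this assay, > 0.1 nM, so its steps to compound 2 and to compound 3 cannot be read (the limit of > 0.1 nM in this assay, at which 1 of the 3 values shown sits). Among the two readable numbers, compound 3 therefore stands highest, with compound 2 as its only neighbour.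

Compound 4 `Cn1cncc1C(OCc1ccc(C#N)cc1-c1ccc(C#N)cc1)c1ccc(C#N)cc1` is the next step from compound 3: 4-cyanophenyl in place of 4-phenylbut-1-yn-1-yl on an aromatic carbon. Going by the values given here, the only measured step at this position is the one from compound 2 to compound 3, which was modest; compound 1, which carries a pyridin-2-yl on the triple-bonded carbon at the same place, reached only a limit. The expected direction for compound 4 is a lower number, and the expected size of the step is a 6.5-fold lower number from compound 3 to compound 4 (0.81 log units; beyond the scatter). Compound 4 is estimated at 20 nM, within a range of 3 nM to 150 nM.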

Compound 4, half-maximal effective concentration: < 0.1 nM
Compound 4: a limit, no number (the forecaster's own chance of this, stated with the estimate: 5%); middle value at least 200-fold (2.30 log units) away from the limit.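

The value of compound 4 is a limit of the assay and not a number: the limit of < 0.1 nM in this assay, at which 1 of the 4 values shown sits. Even so, 4-cyanophenyl on this aromatic carbon gives an at least 1300-fold lower number from compound 3 to compound 4 (3.11 log units; beyond the scatter) in place of 4-phenylbut-1-yn-1-yl, and an at least 160-fold lower number from compound 2 to compound 4 (2.22 log units; beyond the scatter) in place of hepta-1,3-dien-1-yl, both well beyond the only step readable earlier, a 7.8-fold higher number from compound 2 to compound 3 (0.89 log units; beyond the scatter). This position can therefore move the number far more than the earlier pair showed, although the steps involving compound 1 cannot be read. In place of 2-(pyridin-2-yl)ethynyl, 4-cyanophenyl gives only a number no higher from compound 1 to compound 4 (the limit leaves the size open).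

The compounds shown do not separate the loss of the triple-bonded link from the arrival of the nitrile, as a plain phenyl group in the same place would be needed for that. From the compounds shown here alone, whether an amine or a carboxylic acid in place of that nitrile would keep the number at the limit also stays open.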